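The source may report more compounds than this note shows. Statements on the series, on what has been measured and on what is new or still open speak of the compounds shown alone.

Compound 1 `CC(C)CCn1nc(-c2cccs2)c(O)c(C2=NS(=O)(=O)c3cc(N(C)S(C)(=O)=O)ccc3N2)c1=O`: 0.467 h
Compound 2 `COCN(c1ccc2c(c1)S(=O)(=O)N=C(c1c(O)c(-c3cccs3)nn(CCC(C)C)c1=O)N2)S(C)(=O)=O`: 0.183 h
Compound 3 `CC(C)CCn1nc(-c2ccn(C)c2)c(O)c(C2=NS(=O)(=O)c3cc(NS(C)(=O)=O)ccc3N2)c1=O`: 0.633 h

All three values come from an in vitro ADME assay on microsomes from liver (Homo sapiens) for metabolic stability, tested at 5 uM; on this read-out lower numbers stand for a shorter-lived compound and higher numbers for a longer-lived compound. Compound 3 gives 0.633 h, which lies within the scatter of compound 1 at 0.467 h. Compound 2 gives 0.183 h. The gap between compound 2 and compound 3 lies beyond the scatter, with compound 2 the lower of the two.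

Compound 4 `CC(C)CCn1nc(C2=CCCC2)c(O)c(C2=NS(=O)(=O)c3cc(NS(C)(=O)=O)ccc3N2)c1=O` is still unmeasured and differs from compound 3 at one place, an aromatic carbon: cyclopent-1-en-1-yl in place of 1-methyl-1H-pyrrol-3-yl on an aromatic carbon. Cyclopent-1-en-1-yl thus takes the place of 1-methyl-1H-pyrrol-3-yl.

Among the compounds with values here, only one measured step is available, a 2.6-fold lower number from compound 1 to compound 2 (0.41 log units; beyond the scatter). It comes from methoxy in place of hydrogen on a saturated chain carbon bound to a sulfonamide nitrogen, a different place in the molecule, so it gives only a rough idea of how far a single change can move this read-out. Within the data shown here, no measured step exchanges the group on this aromatic carbon, and the direction remains open. The expected result is a 1.4-fold lower number from compound 3 to compound 4 (0.15 log units; within the scatter), with no shift beyond the scatter anticipated.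

Compound 4 is estimated at 0.45 h, with an expected range of 0.18 h to 1.1 h.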

Compound 4, half-life: 0.933 h
Compound 4: middle estimate off by 2.1-fold (0.32 log units), on the low side; measured number inside the range.
By their numbers in this assay, from the lowest: compound 2; then compounds 1, 3 and 4 (each within the scatter of the next).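

Within the data shown here, at this aromatic carbon, next to the ring nitrogen and ortho to the hydroxy group, this assay gives the first measured exchange of the group, a 1.5-fold higher number from compound 3 to compound 4 (0.17 log units; within the scatter). The read-out therefore does not separate the two groups, even though 1-methyl-1H-pyrrol-3-yl is a five-membered aromatic ring with a nitrogen and cyclopent-1-en-1-yl is a non-aromatic ring of carbon only. Nothing among the available data accounts for this outcome.

This single pair cannot show whether the result holds for other groups at this position, such as a saturated cyclopentyl or a phenyl ring. It also leaves open whether the same exchange would give a similar result with a methyl group on the sulfonamide nitrogen, as in compound 1.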